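The compounds below may be only part of what the source reports. "The series", "measured", "known", "first", "only" and "open" are said of these compounds alone.

Measured so far in an assay on CHO cells for displacement of a labelled ligand from adenosine receptor A3 (Homo sapiens), read by scintillation counting, with a stated time of 120 min, tested at 1 uM; on this read-out higher numbers stand for more inhibition at the one concentration tested (going by the name of the read-out) and lower numbers for less inhibition:
compound 1 `N#Cc1c(N)nc(SCc2cccnc2)c(C#N)c1-c1ccc(OCC2CC2)cc1` gives 19%
compound 2 `N#Cc1c(N)nc(SCc2ccn[nH]2)c(C#N)c1-c1ccc(OCC2CC2)cc1` gives 6%
compound 3 `N#Cc1c(N)nc(SCc2nc3ccccc3[nH]2)c(C#N)c1-c1ccc(OCC2CC2)cc1` gives 1%

Compound 3 stands lowest of the three in this assay; its gap to compound 2 lies within the scatter, its gap to compound 1 beyond it. The steps seen so far were a number 13 percentage points lower from compound 1 to compound 2 (beyond the scatter) and a number 18 percentage points lower from compound 1 to compound 3 (beyond the scatter), both modest, while a number 5 percentage points lower from compound 2 to compound 3 (within the scatter) stayed within the scatter. Compound 4 `N#Cc1c(N)nc(SCc2cnc[nH]2)c(C#N)c1-c1ccc(OCC2CC2)cc1` differs from compound 3 by 1H-imidazol-5-yl in place of 1H-benzimidazol-2-yl on a saturated chain carbon bound to a sulfur. The pair of compound 2 and compound 3, a five-membered ring against the fused ring, bears most directly on this change and showed no step beyond the scatter, so no step beyond the scatter is expected here either, in this assay. Compound 4 is estimated at 5% (range 0% to 18%), an expected step of a number 4 percentage points higher from compound 3 to compound 4 (within the scatter).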

Compound 4, a percentage reported as inhibition, at one concentration (the size of the read-out at that concentration, not a potency): 1%
The estimate for compound 4 lay 4 percentage points above the measured number; the range from low to high includes it.
By their numbers in this assay, from the lowest: compounds 3, 4 and 2 (each within the scatter of the next); then compound 1.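

In this assay, 1H-imidazol-5-yl in place of 1H-benzimidazol-2-yl on the saturated chain carbon bound to a sulfur (no change at the digits printed from compound 3 to compound 4 (within the scatter)) shows that losing the six-membered aromatic ring of carbon only leaves the read-out flat. The two five-membered rings also stay within the scatter of each other (a number 5 percentage points lower from compound 2 to compound 4 (within the scatter)), while pyridin-3-yl remains apart (a number 18 percentage points lower from compound 1 to compound 4 (beyond the scatter)). No supporting data explain these steps.

Open, as far as these compounds go, is how an amine or a carboxylic acid on this chain carbon would read. So is whether a longer chain carrying pyridin-3-yl would exceed compound 1.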